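Piperidine amides toward PC-3 cells

The compounds below may be only part of what the source reports. "The series", "measured", "known", "first", "only" and "open" are said of these compounds alone.

Measured compounds:
compound 1 `O=C(Nc1cccc(Oc2ccccn2)c1)C1CCCN(C(=O)c2cc(C(F)(F)F)cc(C(F)(F)F)c2)C1`: 0%
compound 2 `CC(C)(C)CC(=O)Nc1cccc(C(=O)N2CCCC(C(=O)Nc3ccc(Cl)cc3)C2)c1`: 0%

In an ADME assay on PC-3 cells (Homo sapiens) for cytotoxicity, read by WST assay, tested at 100 uM (a higher number here means more inhibition at the concentration tested (going by the name of the read-out), a lower number less inhibition), compound 1 gives 0%. In the same assay compound 2, built as `CC(C)(C)CC(=O)Nc1cccc(C(=O)N2CCCC(C(=O)Nc3ccc(Cl)cc3)C2)c1`, gives 0%. Compound 2 therefore stands level with compound 1 at the digits reported; the two values lie within the scatter of each other, and nothing distinguishes them in this read-out.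

The next compound, compound 3 `O=C(c1ccccc1)c1cccc(C(=O)N2CCCC(C(=O)Nc3ccc(Cl)cc3)C2)c1`, follows from compound 2 by one change on the aromatic ring: benzoyl in place of (neopentylcarbonyl)amino on an aromatic carbon. Among the measured compounds shown here, since both measured compounds sit at the floor of the scale, there is no measured step to guide an expectation for the size of this move; the step from compound 2 to compound 3 in this assay is expected to be none beyond the scatter, a number 2 percentage points higher from compound 2 to compound 3 (within the scatter). For compound 3 the estimated value is 2%, expected to fall between 0% and 15%.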

Compound 3, a percentage reported as inhibition, at one concentration (the size of the read-out at that concentration, not a potency): 0%
Compound 3: the middle estimate sits 2 percentage points above what was measured; measured number inside the range.
By their numbers in this assay, from the lowest: compounds 1, 2 and 3 (each within the scatter of the next).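

In this assay the exchange of benzoyl for (neopentylcarbonyl)amino on an aromatic carbon, meta to a large group, gives no change at the digits printed from compound 2 to compound 3 (within the scatter) even though the entering group adds a six-membered aromatic ring of carbon only and removes the hydrogen-bond donor. At this position, then, neither that ring nor that donor separates the two compounds in this read-out, which stays at the bottom of its scale for both. No supporting measurement is available to account for this flat result.

As far as these compounds go, whether an amine or a carboxylic acid on this same aromatic carbon would lift the read-out off the bottom of the scale remains open. With compounds 1, 2 and 3 all level, the compounds shown do not reveal which part of the structure, if any, could move this number.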